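A few compounds are considered here, and "the series" means these few. Any claim that something is new, unique, unknown or untested is made for them only; others in the source may bear on it.

Working notes on an ADME assay on Huh-7 cells (Homo sapiens) for cytotoxicity, with a stated time of 72 h; a higher number here means that more compound is tolerated, a lower number that less compound is tolerated. Compound 1 `CS(=O)(=O)Nc1ccc2c(c1)S(=O)(=O)N=C(C1=C(O)C3CCCC3N(CCC3CC3)C1=O)N2` stands at a limit, > 33000 nM, and has no exact number. Compound 2 `CS(=O)(=O)Nc1ccc2c(c1)S(=O)(=O)N=C(C1=C(O)[C@H]3CCC[C@H]3N(Cc3ccc(F)c(Cl)c3)C1=O)N2` is likewise only a limit, > 1000 nM. Compound 3 `CS(=O)(=O)Nc1ccc2c(c1)S(=O)(=O)N=C(C1=C(O)C3CCCC3N(CC3CCC3)C1=O)N2` has the same atoms as compound 1, joined differently: cyclobutyl in place of cyclopropylmethyl on a saturated chain carbon bound to an amide-type nitrogen in a ring, with cyclobutyl in place of cyclopropylmethyl on a saturated chain carbon bound to an amide-type nitrogen in a ring. Among the compounds with values here, no measured step bears on this change, and no shift beyond the scatter is expected in this assay, in either direction. The expected step is a number no higher from compound 1 to compound 3 (the limit leaves the size open). Compound 3 is estimated at 33000 nM, with an expected range of 16000 nM to 66000 nM.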

Compound 3, half-maximal cytotoxic concentration: > 33000 nM
Compound 3: no number, only a limit; the forecaster's own chance of this, stated with the estimate: 75%; the middle value sits exactly at the limit.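

No step can be read from compound 1 to compound 3, as each value is only a limit. The compounds shown leave open whether cyclobutyl in place of cyclopropylmethyl changes the half-maximal cytotoxic concentration at all.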